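A few compounds are considered here, and "the series" means these few. Any claim that something is new, unique, unknown or untested is made for them only; others in the source may bear on it.

Measured compounds:
compound 1, `Nc1ccccc1NC(=O)c1ccc(CSC(=S)N2CCN(c3ccccc3)CC2)cc1`, 88.6%
compound 2, `COc1ccc(N2CCN(C(=S)SCc3ccc(C(=O)Nc4ccccc4N)cc3)CC2)cc1`, 35.9%
compound 3, `Nc1ccccc1NC(=O)c1ccc(CSC(=S)N2CCN(c3ccc(F)cc3)CC2)cc1`, 76.3%

In a functional assay on A-375 cells (Homo sapiens) for antiproliferative activity, read by CCK-8 assay, with a stated time of 72 h, tested at 8 uM (on this read-out higher numbers stand for a stronger effect at the one concentration tested and lower numbers for a weaker effect), compound 3 stands second of the three: compound 1 lies above it by a number 12.3 percentage points lower from compound 1 to compound 3 (beyond the scatter), and compound 2 lies below it by a number 40.4 percentage points higher from compound 2 to compound 3 (beyond the scatter), both gaps beyond the scatter. The step from compound 3 to compound 4, `Nc1ccccc1NC(=O)c1ccc(CSC(=S)N2CCN(Cc3ccncc3)CC2)cc1`, is (pyridin-4-yl)methyl in place of 4-fluorophenyl on an amine nitrogen in a ring. All three measured steps sit at this same ring nitrogen, so they bear on the step, though none exchanges the whole aryl group for a methyl-linked heteroaryl. For the measured compounds named here, two of them leave compound 1: a number 52.7 percentage points lower from compound 1 to compound 2 (beyond the scatter) was large and a number 12.3 percentage points lower from compound 1 to compound 3 (beyond the scatter) was modest, so every change made at this place so far has lowered the number in this assay. Going by the values given here, since the new group is a larger departure from compound 1 than a fluoro substituent, a drop beyond the scatter is expected for compound 4, of a size between the two measured drops, with wide uncertainty because no measured step exchanges the aryl group itself. Compound 4 is therefore estimated at 50%, within 20% to 78%, which means an expected step of a number 26.3 percentage points lower from compound 3 to compound 4 (beyond the scatter).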

Compound 4, a percentage reported as inhibition, at one concentration (the size of the read-out at that concentration, not a potency): 89.5%
Compound 4: the middle estimate sits 39.5 percentage points below what was measured; the measured number lies above the stated range.
By their numbers in this assay, from the lowest: compound 2; then compound 3; then compounds 1 and 4 (each within the scatter of the next).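

In this assay, for the compounds shown here, the exchange of 4-fluorophenyl for (pyridin-4-yl)methyl on the amine nitrogen in the ring gives a number 13.2 percentage points higher from compound 3 to compound 4 (beyond the scatter) and the same exchange from 4-methoxyphenyl gives a number 53.6 percentage points higher from compound 2 to compound 4 (beyond the scatter), so this is the first change at this position that does not leave the number under that of compound 1. Set against the plain phenyl group, the new group gives a number 0.9 percentage points higher from compound 1 to compound 4 (within the scatter) and the two compounds stand level, which shows that this nitrogen accepts a change of the whole aryl group, including its attachment through a methyl link and a ring with a hetero atom, while both substituted phenyl groups shown fall short of the plain phenyl group. Nothing available here accounts for this result.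

As far as these compounds go, it remains open whether the level number of compound 4 goes with the methyl link or with the pyridine ring, a question that a benzyl group or a pyridin-4-yl group set directly on the nitrogen would address. From the compounds shown here alone, how far this position extends beyond rings is also open, for example to a longer chain ending in an amine or a carboxylic acid.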